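Swapping the methoxyethyl for chloro on the pendant aryl ring

The source may hold more compounds than are shown below. What is called first, only, known or untested is meant among the compounds shown, and "the series" means these compounds.

Measured compounds:
- compound 3, `CCCC(C)n1c(CC)nc2c(-c3ccc(C(C)OC)cc3Cl)ccnc21`: 3.5 nM
- compound 2, `CCC(CCOC)n1c(C2CC2)nc2c(-c3ccc(C(F)(F)F)cc3Cl)ccnc21`: 20.8 nM
- compound 1, `CCC(CCOC)n1c(COC)nc2c(-c3ccc(C(F)(F)F)cc3Cl)ccnc21`: 82.7 nM

In an assay for binding affinity to Corticotropin releasing factor receptor (Rattus norvegicus) (a higher number here means a weaker inhibitor, a lower number a stronger inhibitor), compound 3 gives 3.5 nM, the lowest number of the three. Compound 2 gives 20.8 nM and compound 1 gives 82.7 nM, so compound 3 stands clearly apart from both. Going by the values given here, the one step between measured compounds, a 4.0-fold lower number from compound 1 to compound 2 (0.60 log units; beyond the scatter), concerns a substituent on the shared core, not the pendant aryl ring, so it does not bear directly on what follows.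

Compound 4, `CCCC(C)n1c(CC)nc2c(-c3ccc(Cl)cc3Cl)ccnc21`, differs from compound 3 by chloro in place of 1-methoxyethyl on an aromatic carbon. Among the compounds with values here, no measured pair isolates this change; compounds 2 and 3 carry different groups at that position but also differ elsewhere, so their values show only that both arrangements give a low number. On that basis the step from compound 3 to compound 4 is expected to be small, a 1.4-fold higher number from compound 3 to compound 4 (0.15 log units; within the scatter), and compound 4 is estimated at 5 nM, with a range from 1.5 nM to 20 nM in this assay.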

Compound 4, inhibition constant: 0.5 nM
For compound 4 the middle estimate is 10-fold (1.00 log units) above the measured one, outside the stated range (below it).
By their numbers in this assay, from the lowest: compound 4; then compound 3; then compound 2; then compound 1.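

In this assay, going by these compounds alone, the pair isolates this position for the first time: chloro in place of 1-methoxyethyl, on the aromatic carbon para to a large group and meta to a chloro group, gives a 7.0-fold lower number from compound 3 to compound 4 (0.85 log units; beyond the scatter). The position is therefore not indifferent to its substituent on this shared core, and a low number there does not depend on the hydrogen-bond acceptor or the four heavy atoms of 1-methoxyethyl, since a single chlorine gives a lower one. No measurement shown here accounts for the difference.

From the compounds shown here alone, whether a fluoro, a methyl or a dimethylamino group at this place would track chloro or 1-methoxyethyl remains open. So does how trifluoromethyl, carried by compound 1 and compound 2 alongside other changes, would compare on the core of compound 4.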